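Shared urea change, a second core, expected potency

A few compounds are considered here, and "the series" means these few. Any claim that something is new, unique, unknown or untested is made for them only; others in the source may bear on it.

Measured compounds:
compound 1, `CN(C)CCNc1nc(-c2ccc(NC(=O)Nc3ccc(Cl)cc3Cl)cc2)nc2ccsc12` — 1650 nM
compound 2, `Cc1ccc(NC(=O)Nc2ccc(-c3nc(NCCN(C)C)c4sccc4n3)cc2)cc1` — 1880 nM
compound 3, `CCN(CC)CCNc1nc(-c2ccc(NC(=O)Nc3ccc(Cl)cc3Cl)cc2)nc2c(Cl)c(Cl)sc12` — 1300 nM

Compound 1 and compound 2 were tested in a functional assay on NCI-H460 cells (Homo sapiens) for cytotoxicity, read by MTT assay, with a stated time of 72 h; on this read-out higher numbers stand for weaker inhibition and lower numbers for stronger inhibition; in this assay compound 1 gives 1650 nM and compound 2 gives 1880 nM. The change between them is 4-methylphenyl in place of 2,4-dichlorophenyl on an amide-type nitrogen, and its step was a 1.1-fold higher number from compound 1 to compound 2 (0.06 log units; within the scatter). Compound 3 carries a different core; the difference between the two cores is not broken down here. In this assay compound 3 gives 1300 nM. Compound 4, `CCN(CC)CCNc1nc(-c2ccc(NC(=O)Nc3ccc(C)cc3)cc2)nc2c(Cl)c(Cl)sc12`, has not been measured; it differs from compound 3 by 4-methylphenyl in place of 2,4-dichlorophenyl on an amide-type nitrogen, the same change as from compound 1 to compound 2. Because that earlier step was a 1.1-fold higher number from compound 1 to compound 2 (0.06 log units; within the scatter), the step is expected to be similar, a 1.2-fold higher number from compound 3 to compound 4 (0.06 log units; within the scatter). Compound 4 is therefore estimated at 1500 nM, likely between 700 nM and 3200 nM.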

Compound 4, half-maximal inhibitory concentration: 840 nM
Compound 4: middle estimate off by 1.8-fold (0.25 log units), on the high side; low and high end bracket the measured number.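

On the second core, 4-methylphenyl in place of 2,4-dichlorophenyl on an amide-type nitrogen gives, in this assay, a 1.5-fold lower number from compound 3 to compound 4 (0.19 log units; within the scatter). Set beside the same change on the first core, this step cannot be told apart from the earlier one: the same change on two cores in this assay, a 1.1-fold higher number (0.06 log units; within the scatter) from compound 1 to compound 2 and a 1.5-fold lower number (0.19 log units; within the scatter) from compound 3 to compound 4, 1.8-fold (0.25 log units) apart, within the scatter of two such steps

Within these two pairs, then, the change behaves alike on both cores, but neither step is large enough to show that the change has any real effect, and two pairs cannot show that this would hold on further cores.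

The compounds shown leave open whether a phenyl group carrying a carboxylic acid or an amine, in place of these two groups, would shift the number beyond the scatter.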